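The source may hold more compounds than are shown below. What is called first, only, known or untested is meant among the compounds shown, and "the series" means these compounds.

Compound 1 `CCc1ccccc1OS(=O)(=O)c1ccc(N2CCN(C)C2=O)cc1`: in a functional assay on HT-29 cells (Homo sapiens) for antiproliferative activity, read by sulforhodamine B assay, with a stated time of 48 h (a lower number here means a stronger inhibitor, a higher number a weaker inhibitor), compound 1 gives 4600 nM.
Compound 2 `CCN1CCN(c2ccc(S(=O)(=O)Oc3cccc(OC)c3)cc2)C1=O`: compound 2 gives 22000 nM.
Compound 3 `CCCN1CCN(c2ccc(S(=O)(=O)Oc3ccccc3CC)cc2)C1=O`: compound 3 gives only a limit, > 100000 nM, the upper bound of the assay (the limit of > 100000 nM in this assay, at which 1 of the 3 values shown sits).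

Going by the values given here, compound 3 thus stands at the weak end of the three, with no number of its own; the only step reaching it, an at least 21-fold higher number from compound 1 to compound 3 (1.33 log units; beyond the scatter), is large. Compound 4 `CCCN1CCN(c2ccc(S(=O)(=O)Oc3ccc(OC)cc3)cc2)C1=O` differs from compound 3 by 4-methoxyphenyl in place of 2-ethylphenyl on an oxygen. Among the compounds with values here, no measured step isolates this change; compound 1 and compound 2 differ in two places at once and do not separate it. Compound 4 is therefore expected to stay near compound 3, with a number no higher from compound 3 to compound 4 (the limit leaves the size open) not beyond the scatter. Compound 4 is estimated at 100000 nM, within 30000 nM to 300000 nM.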

Compound 4, half-maximal inhibitory concentration: 16000 nM
Compound 4: the middle estimate sits 6.3-fold (0.80 log units) above what was measured; measured number outside the range, below it.
By their numbers in this assay, from the lowest: compound 1; then compounds 4 and 2 (each within the scatter of the next). At a limit, above all of these: compound 3.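

In this assay, the group on the oxygen bound to the sulfonyl sulfur clearly matters: 4-methoxyphenyl in place of 2-ethylphenyl gives an at least 6.2-fold lower number from compound 3 to compound 4 (0.79 log units; beyond the scatter). With everything else in compound 3 unchanged, this single change restores a measurable number, so the chain on the core does not alone decide the outcome. Compound 3 carries a limit, not a number, and the full size of the step stays open: the limit of > 100000 nM in this assay, at which 1 of the 4 values shown sits.

The step does not separate the identity of the substituent from its place on the ring. Neither 2-methoxyphenyl nor 4-ethylphenyl appears among the compounds shown, and either would help to divide those two contributions.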